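Removing a methyl from an aryl ether in diaryl ureas

The source may hold more compounds than are shown below. What is called first, only, known or untested is meant among the compounds shown, and "the series" means these compounds.

Measured compounds:
- compound 1, `COc1cc(NC(=O)Nc2cc(C(F)(F)F)cc(C(F)(F)F)c2)ccc1C`: 6600 nM
- compound 2, `COc1cc(NC(=O)Nc2ccc(Cl)c(Cl)c2)ccc1C`: only a limit, > 20000 nM
- compound 3, `Cc1ccc(NC(=O)Nc2ccc(Cl)c(Cl)c2)cc1O`: only a limit, > 20000 nM

All three compounds are diaryl ureas that were tested in a functional assay on cells (Mus musculus) for antiproliferative activity, read by sulforhodamine B assay, with a stated time of 5 days; on this read-out lower numbers stand for stronger inhibition and higher numbers for weaker inhibition. Compound 1 gives 6600 nM in this assay. Compound 2 reaches only a limit of the assay, > 20000 nM, and no number. Compound 3 likewise reaches only a limit, > 20000 nM. The difference between the core of compound 1 and the core of compound 2 is not broken down here.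

Compound 3 differs from compound 2 by one change: hydrogen in place of methyl on an oxygen on an aromatic ring. The step this change made in this assay is a step that the two limits leave unreadable from compound 2 to compound 3, since both compounds sit at the limit (the limit of > 20000 nM in this assay, at which 2 of the 3 values shown sit).

Compound 4, `Cc1ccc(NC(=O)Nc2cc(C(F)(F)F)cc(C(F)(F)F)c2)cc1O`, has not yet been measured in this assay. It differs from compound 1 by the same change, (hydrogen in place of methyl on an oxygen on an aromatic ring), made at the same place on the core. Going by the values given here, the one earlier example of this change gives no readable size, so the expectation for compound 4 rests on compound 1 and its value 6600 nM alone, with the change assumed to move potency little either way. The step from compound 1 to compound 4 is expected to be a 1.4-fold higher number from compound 1 to compound 4 (0.13 log units; within the scatter). Compound 4 is therefore estimated to give 9000 nM in this assay, between 3000 nM and 30000 nM.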

Compound 4, half-maximal inhibitory concentration: 15700 nM
Compound 4: middle estimate off by 1.7-fold (0.24 log units), on the low side; the range from low to high includes it.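

In this assay, replacing methoxy with hydroxy on the core of compound 1 gives a 2.4-fold higher number from compound 1 to compound 4 (0.38 log units; beyond the scatter), so on this core the change weakens inhibition modestly. This is the only readable size for the change in the series, and one pair of compounds sets no rule for how it behaves on other cores. The same change on the core of compound 2 cannot be read, because compound 2 and compound 3 each give only a limit and no number, so it stays unknown whether the two cores respond alike: the limit of > 20000 nM in this assay, at which 2 of the 4 values shown sit.

The compounds shown leave open what would happen with a longer chain such as ethyl or propyl in place of methyl on this oxygen, or with an amine in place of the hydroxy group on the aromatic ring. They also leave open whether the step from methoxy to hydroxy would keep its size on a core with stronger inhibition than compound 1, which gives 6600 nM.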